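Methoxy added to an aryl imine on a pyrazolone core

The compounds below may be only part of what the source reports. "The series", "measured", "known", "first", "only" and "open" are said of these compounds alone.

Three compounds were measured in a functional assay on DLD-1 cells (Homo sapiens) for cytotoxicity, read by MTT assay, with a stated time of 72 h; a lower number here means a stronger inhibitor, a higher number a weaker inhibitor. Compound 3 `Cc1c(/N=C/c2ccccc2)c(=O)n(-c2ccccc2)n1C` gives 933000000 nM. Compound 2 `COc1ccccc1/C=N/c1c(C)n(C)n(-c2ccccc2)c1=O` gives 933000000 nM, and compound 1 `COc1ccc(/C=N/c2c(C)n(C)n(-c3ccccc3)c2=O)cc1OC` gives 676000000 nM. The difference between the cores of compound 1 and compound 3 is not broken down here. Between compound 3 and compound 2 the change is methoxy in place of hydrogen on an aromatic carbon, and the step of no change at the digits printed from compound 3 to compound 2 (within the scatter).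

Compound 4 `COc1cc(/C=N/c2c(C)n(C)n(-c3ccccc3)c2=O)cc(OC)c1OC` has not yet been measured in this assay. It differs from compound 1 by methoxy in place of hydrogen on an aromatic carbon. This is the same kind of change as that from compound 3 to compound 2, but the surroundings of the place differ: in compound 2 the entering group sits ortho to a large group, whereas in compound 4 it sits ortho to a methoxy group, meta to a large group and meta to a methoxy group.

Because the earlier step of no change at the digits printed from compound 3 to compound 2 (within the scatter), the step from compound 1 to compound 4 in this assay is expected to be a 1.0-fold higher number from compound 1 to compound 4 (0.02 log units; within the scatter). Compound 4 is therefore estimated to give 700000000 nM, with a range from 300000000 nM to 2000000000 nM.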

Compound 4, half-maximal inhibitory concentration: 501000000 nM
Estimate against measurement, compound 4: 1.4-fold (0.15 log units) above, within the range that was stated.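

In this assay, methoxy in place of hydrogen on an aromatic carbon gives a 1.3-fold lower number from compound 1 to compound 4 (0.13 log units; within the scatter). Set beside the earlier case, the same change on a second core shows no difference that stands out from the scatter: the same change on two cores in this assay, no change at the digits printed (within the scatter) from compound 3 to compound 2 and a 1.3-fold lower number (0.13 log units; within the scatter) from compound 1 to compound 4, 1.3-fold (0.13 log units) apart, within the scatter of two such steps. This agreement shows only that, for these two pairs, the change leaves the number within the scatter on both cores; it does not show that methoxy has any effect on cytotoxicity here, and two small steps at differently surrounded places, one of them ortho to a methoxy group in compound 4, make no rule for other cores or other places.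

The only group entering in these steps is methoxy, so the compounds shown leave open whether an amine, a carboxylic acid or a longer chain on the same aromatic ring would give a step beyond the scatter. They also leave open whether any such step would carry from one core to the other as the methoxy step does.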